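The source may report more compounds than this note shows. Statements on the series, on what has been measured and on what is new or still open speak of the compounds shown alone.

Measured compounds:
- compound 1, `C=C(Br)C(=O)Nc1ccc2oc(C(=O)NCCNC(=O)c3cc(OCC4(c5ccc(-c6ccccc6)cc5)CC(=C)C(=O)O4)nn3C)cc2c1`: 410 nM
- compound 2, `C=C(Br)C(=O)Nc1ccc2sc(C(=O)NCCNC(=O)c3cc(OCC4(c5ccc(Cl)cc5)CC(=C)C(=O)O4)nn3C)cc2c1`: 410 nM
- compound 3, `C=C(Br)C(=O)Nc1ccc2c(c1)cc(C(=O)O)n2C`: 3370 nM

In a functional assay on K562 cells (Homo sapiens) for antiproliferative activity (on this read-out higher numbers stand for weaker inhibition and lower numbers for stronger inhibition), compound 1 gives 410 nM, level with compound 2 at the digits shown and, together with it, the lowest of the three numbers; compound 3 sits far higher, well beyond the scatter. Compound 4, `C=C(Br)C(=O)Nc1ccc2oc(C(=O)NCCNC(=O)c3cc(OCC4(c5ccc(Cl)cc5)CC(=C)C(=O)O4)nn3C)cc2c1`, is compound 1 with one change: chloro in place of phenyl on an aromatic carbon. For the measured compounds named here, no measured pair isolates this exact change. Compound 2, which carries the same chloro group but a different core, gives 410 nM, the same number as compound 1. The expectation is therefore no step beyond the scatter, a 1.1-fold higher number from compound 1 to compound 4 (0.04 log units; within the scatter). Compound 4 is expected to give about 450 nM in this assay, most likely between 200 nM and 1000 nM.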

Compound 4, half-maximal inhibitory concentration: 710 nM
Estimate against measurement, compound 4: 1.6-fold (0.20 log units) below; the measured number falls inside the stated range.
By their numbers in this assay, from the lowest: compounds 1, 2 and 4 (each within the scatter of the next); then compound 3.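

In this assay, replacing the 4-phenylphenyl group with 4-chlorophenyl gives a 1.7-fold higher number from compound 1 to compound 4 (0.24 log units; within the scatter) and so stays within the scatter. For the compounds shown here, on the core of compound 1, then, this position tolerates losing the outer phenyl ring, a direct comparison that the earlier compounds could not provide. Nothing measured here explains this result. Still open, going by these compounds, is whether an amine or a methoxy group at this place would give a similar number. On these data alone, it is also open whether the same change from 4-phenylphenyl to 4-chlorophenyl would behave alike on the core of compound 2.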